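The source may hold more compounds than are shown below. What is called first, only, known or untested is meant among the compounds shown, and "the series" means these compounds.

Compound 1, `O=C(Nc1ccc(Sc2nc3ccccc3s2)c(Cl)c1)c1ccccc1O`: in an assay for inhibition of HSP60/HSP10 (Homo sapiens), with a stated time of 60 min (a lower number here means a stronger inhibitor, a higher number a weaker inhibitor), compound 1 gives > 100000 nM, which is a limit of the assay.
Compound 2, `COc1c(Br)cccc1C(=O)Nc1ccc(Sc2nc3ccccc3s2)c(Cl)c1`: in this assay compound 2 gives > 100000 nM, again a limit.
Compound 3, `O=C(Nc1ccc(Sc2nc3ccccc3s2)cc1)c1cccc(Br)c1`: in this assay compound 3 gives > 100000 nM, also a limit.

Compound 2 thus stands at the upper limit of this assay, as do the other two measured compounds; all three sit at the limit of > 100000 nM in this assay, at which 3 of the 3 values shown sit. Among the measured compounds shown here, the only single-point step among them, a step that the two limits leave unreadable from compound 1 to compound 2, is unreadable, since both ends are limits. Compound 4, `O=C(Nc1ccc(Sc2nc3ccccc3s2)c(Cl)c1)c1cccc(Br)c1O`, differs from compound 2 by hydrogen in place of methyl on an oxygen on an aromatic ring. For the measured compounds named here, no measured step bears on this change directly, and the values of compound 1 and compound 3 are themselves limits rather than numbers. Compound 4 is therefore expected to remain at the limit as well, an expected step that the limit leaves unreadable from compound 2 to compound 4 from a limit. The estimate for compound 4 in this assay is 200000 nM, with a range from 50000 nM to 1000000 nM.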

Compound 4, half-maximal inhibitory concentration: 6900 nM
Beside the measured number, compound 4's estimate is 29-fold (1.46 log units) above it; measured number below the stated range.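

In this assay compound 4 gives 6900 nM, the only value among the compounds shown that is not a limit: the limit of > 100000 nM in this assay, at which 3 of the 4 values shown sit. The change from methoxy to hydroxy on the aromatic ring carries an at least 14-fold lower number from compound 2 to compound 4 (1.16 log units; beyond the scatter), so this single methyl on the oxygen separates a measurable inhibitor from a compound at the limit. Bromo in place of hydrogen on an aromatic carbon carries an at least 14-fold lower number from compound 1 to compound 4 (1.16 log units; beyond the scatter), so among these compounds a number appears only where hydroxy and bromo stand together.

What the compounds shown leave open is whether an amine or a carboxylic acid could stand in place of the hydroxy, or iodo in place of the bromo. Going by these compounds, it also stays open whether compound 4 would keep its activity without the chloro on its core.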